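The source may hold more compounds than are shown below. What is called first, only, known or untested is meant among the compounds shown, and "the series" means these compounds.

Measured in a functional assay on HEK293 cells for agonist activity at Bile acid receptor (Homo sapiens), read by a luciferase reporter; on this read-out higher numbers stand for larger maximal responses and lower numbers for smaller maximal responses:
compound 1 `CC(C)c1onc(-c2c(Cl)cccc2Cl)c1COc1ccc(C(=O)N(c2cccc(C(=O)O)c2)c2cccc3ccccc23)c(Cl)c1` — 28%
compound 2 `CC(C)c1onc(-c2c(Cl)cccc2Cl)c1COc1ccc(C(=O)N(C)c2cccc(C(=O)O)c2)c(Cl)c1` — 45%
compound 3 `CC(C)c1onc(-c2c(Cl)cccc2Cl)c1COc1ccc(N(C(=O)c2cccc(C(=O)O)c2)c2cccc3ccccc23)c(Cl)c1` — 35%

On these numbers compound 2 stands highest of the three in this assay. Compound 3 sits nearest, within the usual scatter, so no order between compound 2 and compound 3 can be claimed. Among the measured compounds shown here, compound 1 sits furthest, beyond the scatter, and the one single-point step in the set runs a number 17 percentage points higher from compound 1 to compound 2 (beyond the scatter).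

Compound 4 `CC(C)c1onc(-c2c(Cl)cccc2Cl)c1COc1ccc(C(=O)N(Cc2ccccc2)c2cccc(C(=O)O)c2)c(Cl)c1` differs from compound 2 by phenyl in place of hydrogen on a saturated chain carbon bound to an amide-type nitrogen. For the measured compounds named here, only the step from compound 1 to compound 2 bears on this: the amide-type nitrogen carried naphthalen-1-yl in compound 1 and methyl in compound 2, and the change raised the maximal response by a modest amount. Compound 4 carries benzyl on that nitrogen, which lies between the two measured substituents in the words of the difference. The expected direction for compound 4 in this assay is therefore downward from compound 2, with the step of a number 9 percentage points lower from compound 2 to compound 4 (within the scatter) estimated to be of smaller size than the measured one and possibly within the scatter. Compound 4 is accordingly estimated at 36%, with a range from 22% to 50%.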

Compound 4, largest response reached (reported as efficacy), in percent of the reference or control that the assay uses: 31%
Estimate against measurement, compound 4: 5 percentage points above; the range from low to high includes it.
By their numbers in this assay, from the lowest: compounds 1, 4, 3 and 2 (each within the scatter of the next, the first and the last beyond it).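

In this assay, extending methyl to benzyl on the amide-type nitrogen lowers the maximal response (a number 14 percentage points lower from compound 2 to compound 4 (beyond the scatter)), so the loss relative to methyl is not confined to naphthalen-1-yl. Benzyl and naphthalen-1-yl cannot be separated on this read-out (a number 3 percentage points higher from compound 1 to compound 4 (within the scatter)), and among the three substituents on this nitrogen only methyl stands apart, with both aromatic groups beyond the scatter from it. No supporting data bear on why the response changes with this substituent.

Open, from the compounds shown here alone, is whether hydrogen, ethyl or a longer chain on this nitrogen, or a chain ending in an amine, would match or exceed the response of compound 2. Also open, going by these compounds, is whether a fluorine or methoxy group on the phenyl of the benzyl would shift the response of compound 4.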